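Replacing the Acetylphenyl Group on the Piperazine-Type Amide

The source may hold more compounds than are shown below. What is called first, only, known or untested is meant among the compounds shown, and "the series" means these compounds.

Compound 1 `COc1cc(OC)cc(N2CCN(C(=O)c3onc(C)c3-c3ccccc3)CC2)c1` gives 152 nM 
Compound 2 `CC(=O)c1ccc(N2CCN(C(=O)c3oc(C)nc3-c3ccccc3)CC2)cc1` gives "not active" (no number reported) 
Compound 3 `Cc1ccc(C)c(N2CCN(C(=O)c3oc(C)nc3-c3cccc(Cl)c3)CC2)c1` gives 345 nM 

These results come from a functional assay on HL-60 cells (Homo sapiens) for inhibition, read by MTT assay, with a stated time of 72 h; on this read-out lower numbers stand for stronger inhibition and higher numbers for weaker inhibition. In this assay compound 2 is recorded as "not active" (no number reported) and has no number, so it stands without a numerical position among the three. Compound 4 `Cc1nc(-c2ccccc2)c(C(=O)N2CCN(c3ccccc3C(F)(F)F)CC2)o1` has not yet been measured. The structural change 2-(trifluoromethyl)phenyl in place of 4-acetylphenyl on an amine nitrogen in a ring puts 2-(trifluoromethyl)phenyl in place of 4-acetylphenyl on an amine nitrogen in a ring. Within the data shown here, no measured pair shows this change, and the size of the step cannot be expressed as a number while compound 2 has none. A clear step towards stronger inhibition is nevertheless expected, to a measurable value. That expectation leans on compound 3 at 345 nM and compound 1 at 152 nM in the same assay, since both carry other substituted phenyl groups on that nitrogen and both give numbers. For compound 4 an estimated 500 nM is expected (range 100 nM to 3000 nM).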

Compound 4, half-maximal inhibitory concentration: 120 nM
For compound 4 the middle estimate is 4.2-fold (0.62 log units) above the measured one; the range from low to high includes it.
By their numbers in this assay, from the lowest: compounds 4 and 1 (each within the scatter of the next); then compound 3.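

In this assay, among these compounds, compound 4 gives 120 nM and compound 2 has no number, so no step between compound 2 and compound 4 can be read. The compounds shown leave open what 2-(trifluoromethyl)phenyl alone contributes to inhibition, and no measured evidence bears on this result.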